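A few compounds are considered here, and "the series" means these few. Any claim that something is new, unique, unknown or untested is made for them only; others in the source may bear on it.

Measured compounds:
compound 1, `CC(C)c1ccc(Nc2ccc3c(OCCCN4CCN(C)CC4)cccc3n2)cc1`, 11300 nM
compound 2, `CN1CCN(CCCOc2cccc3nc(Nc4ccc(F)c(F)c4)ccc23)CC1`, 2350 nM
compound 3, `CN1CCN(CCCOc2cccc3nc(Nc4cccc(Cl)c4)ccc23)CC1`, 1780 nM

All three share one core and differ only in the phenyl group carried on a nitrogen on an aromatic ring; the numbers come from a functional assay on KM12 cells (Homo sapiens) for inhibition, read by sulforhodamine B assay, with a stated time of 48 h; on this read-out lower numbers stand for stronger inhibition of growth and higher numbers for weaker inhibition of growth. Compound 3 has the lowest number of the three. One of its steps is a 1.3-fold lower number from compound 2 to compound 3 (0.12 log units; within the scatter), so these two cannot be told apart, while the other is a 6.3-fold lower number from compound 1 to compound 3 (0.80 log units; beyond the scatter). Compound 4, `CN1CCN(CCCOc2cccc3nc(Nc4ccc(Cl)c(C(F)(F)F)c4)ccc23)CC1`, is not yet measured. It differs from compound 3 in a single place: 4-chloro-3-(trifluoromethyl)phenyl in place of 3-chlorophenyl on a nitrogen on an aromatic ring. Every measured step changes this same phenyl group. Replacing 4-isopropylphenyl gave a 4.8-fold lower number from compound 1 to compound 2 (0.68 log units; beyond the scatter) and a 6.3-fold lower number from compound 1 to compound 3 (0.80 log units; beyond the scatter), whereas exchanging one of the other two phenyl groups for the other gave a 1.3-fold lower number from compound 2 to compound 3 (0.12 log units; within the scatter). The step to compound 4 resembles this second kind, so little movement in this assay is expected, at most a slight shift downward. Compound 4 is therefore expected to give 1500 nM, within 500 nM to 4500 nM, which means an expected step of a 1.2-fold lower number from compound 3 to compound 4 (0.07 log units; within the scatter).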

Compound 4, concentration for 50% growth inhibition: 1740 nM
For compound 4 the middle estimate is 1.2-fold (0.06 log units) below the measured one, and the stated range covers the measured number.
By their numbers in this assay, from the lowest: compounds 4, 3 and 2 (each within the scatter of the next); then compound 1.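

In this assay, exchanging 3-chlorophenyl for 4-chloro-3-(trifluoromethyl)phenyl on this nitrogen takes the group from 7 to 11 heavy atoms, yet the number hardly moves (a 1.0-fold lower number from compound 3 to compound 4 (0.01 log units; within the scatter)) and stays level with the difluorinated analogue as well (a 1.4-fold lower number from compound 2 to compound 4 (0.13 log units; within the scatter)). The larger group keeps the full gap to the 4-isopropylphenyl analogue (a 6.5-fold lower number from compound 1 to compound 4 (0.81 log units; beyond the scatter)), so among these four compounds only compound 1 stands apart, and a much bigger halogen-bearing phenyl group is no worse here than a smaller one. Nothing available explains why these three groups give such similar numbers.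

The compounds shown leave open what a phenyl ring carrying an amine or a carboxylic acid would do at this nitrogen. They also leave open whether any group other than a substituted phenyl ring would be accepted there.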